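Acylhydrazone aryl swap on a shared triazolylpyridine ether core

A few compounds are considered here, and "the series" means these few. Any claim that something is new, unique, unknown or untested is made for them only; others in the source may bear on it.

Measured compounds:
compound 1 `CN(C)CCn1cnnc1-c1cc(Oc2ccc(NC(=O)N/N=C/c3cc(C(C)(C)C)cc(C(C)(C)C)c3O)cc2F)ccn1` with 680 nM
compound 2 `COc1ccc(/C=N/NC(=O)Nc2ccc(Oc3ccnc(-c4nncn4CCN(C)C)c3)c(F)c2)c(OC)c1` with 1780 nM

In a functional assay on HT-29 cells (Homo sapiens) for cytotoxicity, read by MTT assay, with a stated time of 72 h (a lower number here means a stronger inhibitor, a higher number a weaker inhibitor), compound 2 gives 1780 nM, the highest of the two numbers shown; its nearest neighbour is compound 1, which in this assay gives 680 nM, a gap that lies beyond the usual scatter. Compound 3 `CN(C)CCn1cnnc1-c1cc(Oc2ccc(NC(=O)N/N=C/c3ccc(F)cc3)cc2F)ccn1` has not yet been measured. It differs from compound 2 in one place: 4-fluorophenyl in place of 2,4-dimethoxyphenyl on a carbon with a double bond to nitrogen. Going by the values given here, no pair of measured compounds shows this change, so the size of the step cannot be read from the numbers at hand. The step from compound 2 to compound 3 in this assay is expected to be a 1.2-fold lower number from compound 2 to compound 3 (0.07 log units; within the scatter), a change that need not exceed the scatter. Compound 3 is therefore estimated at 1500 nM, within a range from 500 nM to 5000 nM.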

Compound 3, half-maximal inhibitory concentration: 1370 nM
Beside the measured number, compound 3's estimate is 1.1-fold (0.04 log units) above it, and the stated range covers the measured number.
By their numbers in this assay, from the lowest: compounds 1, 3 and 2 (each within the scatter of the next, the first and the last beyond it).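

In this assay the place on a carbon with a double bond to nitrogen now has a measured step: 4-fluorophenyl in place of 2,4-dimethoxyphenyl gives a 1.3-fold lower number from compound 2 to compound 3 (0.11 log units; within the scatter). In this pair, the aromatic ring can therefore lose both methoxy groups and gain a fluorine, going from 2 hydrogen-bond acceptors to 0 and from 10 heavy atoms to 7, without a change beyond the scatter. No measurement shown here accounts for this outcome.

The compounds shown leave open whether an aromatic ring carrying an amine or a carboxylic acid at this place would give a number beyond the scatter of these two. They also leave open whether a saturated ring such as cyclohexyl, in place of the aromatic ring, would be tolerated.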